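Pyrimidinyl thioether replacing imidazolyl thioether on the shared core

The source may hold more compounds than are shown below. What is called first, only, known or untested is meant among the compounds shown, and "the series" means these compounds.

Compound 3 `O=C(CSc1ncc[nH]1)Nc1ccc2nc(NC(=O)c3ccc(C(F)(F)F)cc3)sc2c1` gives 18800 nM in a functional assay on U2OS cells (Homo sapiens) for antiproliferative activity, read by MTT assay, with a stated time of 72 h (on this read-out higher numbers stand for weaker inhibition and lower numbers for stronger inhibition), the highest of the two numbers recorded here. Compound 1 `Nc1ccc(SCC(=O)Nc2ccc3nc(NC(=O)c4ccc(C(F)(F)F)cc4)sc3c2)cc1` gives 1220 nM and is the nearest neighbour. Compound 2 `Cc1cc(C)cc(C(=O)Nc2nc3ccc(NC(=O)CSc4ccc(Cl)cc4)cc3s2)c1` is recorded only as a limit of this assay, > 100000 nM, not as a number. Compound 4 `O=C(CSc1ncccn1)Nc1ccc2nc(NC(=O)c3ccc(C(F)(F)F)cc3)sc2c1` is still unmeasured; it differs from compound 3 at the sulfur as follows: pyrimidin-2-yl in place of 1H-imidazol-2-yl on a sulfur.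

Among the measured compounds shown here, one measured step touches the same sulfur: a 15-fold higher number from compound 1 to compound 3 (1.19 log units; beyond the scatter). For the measured compounds named here, that step runs from 4-aminophenyl to 1H-imidazol-2-yl, so it covers the present change only in part; no measured pair compares a five-membered with a six-membered aromatic ring on this sulfur, and no measured pair removes the hydrogen-bond donor alone. The one limit shown (the limit of > 100000 nM in this assay, at which 1 of the 3 values shown sits) belongs to a different chlorophenyl-substituted scaffold and does not bear on the step.

Going by the values given here, the expectation is therefore set between the two known numbers: compound 4 is expected to return part of the way towards compound 1, with a step of a 2.7-fold lower number from compound 3 to compound 4 (0.43 log units; beyond the scatter). The estimated value for compound 4 in this assay is 7000 nM, with a range from 2000 nM to 25000 nM.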

Compound 4, half-maximal inhibitory concentration: 28100 nM
Compound 4: middle estimate off by 4.0-fold (0.60 log units), on the low side; measured number above the stated range.
By their numbers in this assay, from the lowest: compound 1; then compounds 3 and 4 (each within the scatter of the next). At a limit, above all of these: compound 2.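

In this assay, pyrimidin-2-yl on this sulfur in place of 1H-imidazol-2-yl gives a 1.5-fold higher number from compound 3 to compound 4 (0.17 log units; within the scatter), so a six-membered aromatic ring without a hydrogen-bond donor cannot be told apart from the five-membered ring that carries one. The comparison with 4-aminophenyl shows a 23-fold higher number from compound 1 to compound 4 (1.36 log units; beyond the scatter), in line with a 15-fold higher number from compound 1 to compound 3 (1.19 log units; beyond the scatter), and so among these three groups on the sulfur only compound 1 stands apart, with compounds 3 and 4 together on the weaker side. The hydrogen-bond donor and ring size change together in this step, yet neither change, on these two compounds, separates the values, and nothing shown gives a reason for the distance of both from compound 1.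

As far as these compounds go, it remains open whether the amine of compound 1 or its phenyl ring accounts for that distance, which a plain phenyl group or a 4-hydroxyphenyl group on the same sulfur, on the shared core, would address. A pyridin-2-yl group on this sulfur would also show whether the ring nitrogens of compounds 3 and 4 matter, since the present set changes them only together with the rest of the ring.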